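From nonyl to ethoxycarbonyl in a cytotoxic series

The compounds below may be only part of what the source reports. "The series", "measured", "known", "first", "only" and "open" are said of these compounds alone.

Of the compounds shown here, two have so far been measured in a functional assay on HeLa cells (Homo sapiens) for cytotoxicity, read by MTT assay, with a stated time of 48 h; a lower number here means a stronger inhibitor, a higher number a weaker inhibitor. In this assay compound 1 `O=C(O[C@H]1C[C@H](n2cc(F)c(=O)[nH]c2=O)O[C@@H]1COP(=O)(O)Oc1ccc2ncccc2c1)c1ccccc1` gives 7300 nM, while compound 2 `CCCCCCCCCC[n+]1cccc(OP(=O)([O-])OC[C@H]2O[C@@H](n3cc(F)c(=O)[nH]c3=O)C[C@@H]2OC(=O)c2ccccc2)c1` gives 1200 nM. Compound 2 therefore holds the lower of the two numbers, and its gap to compound 1 lies beyond the usual scatter.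

Still unmeasured, compound 3 `CCOC(=O)C[n+]1cccc(OP(=O)([O-])OC[C@H]2O[C@@H](n3cc(F)c(=O)[nH]c3=O)C[C@@H]2OC(=O)c2ccccc2)c1` differs from compound 2 in one place: ethoxycarbonyl in place of nonyl on a saturated chain carbon bound to an aromatic nitrogen. It carries ethoxycarbonyl in place of nonyl on a saturated chain carbon bound to an aromatic nitrogen. Among the compounds with values here, no measured pair isolates this change, so the size of the step has no direct precedent and any forecast remains uncertain. A move toward a higher number in this assay, beyond the scatter, is nevertheless expected. The only other reference point is compound 1, which has no such long chain and stands at 7300 nM. The estimated change is a 5.0-fold higher number from compound 2 to compound 3 (0.70 log units; beyond the scatter). Compound 3 is expected to give 6000 nM, with an estimated range of 2000 nM to 20000 nM.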

Compound 3, half-maximal inhibitory concentration: 6100 nM
Compound 3: middle estimate off by 1.0-fold (0.01 log units), on the low side, within the range that was stated.
By their numbers in this assay, from the lowest: compound 2; then compounds 3 and 1 (each within the scatter of the next).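

In this assay, within the data shown here, ethoxycarbonyl in place of nonyl on a saturated chain carbon bound to an aromatic nitrogen gives a 5.1-fold higher number from compound 2 to compound 3 (0.71 log units; beyond the scatter), the first direct reading of a change at this position. The rest of the structure is identical in the two compounds, so the lower number of compound 2 depends on what this position carries and is not secured by the shared core alone. The data offer no measurement that explains the step, and its cause remains unknown.

This one pair cannot separate the loss of the plain carbon chain from the entry of the ethoxycarbonyl group, since the same difference, read one bond further out, is decyl to (ethoxycarbonyl)methyl and both parts of the change happen together. The compounds shown leave open where a butyl chain, a longer chain such as dodecyl, or a carboxylic acid in place of the ethoxycarbonyl group would stand, and whether the number follows chain length at all.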